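This account rests on a few compounds, and the source may have more. Where it says the series, first, only, none or still open, it means among the compounds named here.

Within the data shown here, in an ADME assay on microsomes from liver (Mus musculus) for metabolic stability, using NADPH, with a stated time of 10 min (a lower number here means that less of the compound is left, a higher number that more of the compound is left), compound 3 `NC(=O)NC/C=C\CN(C[C@H]1Cc2ncccc2CN1)[C@H]1CCCc2cccnc21` gives 10% as the lowest of the three numbers so far. Compound 1 `NCCCCN(C[C@H]1Cc2ncccc2CN1)[C@H]1CCCc2cccnc21` gives 86% and compound 2 `NC/C=C/CN(C[C@H]1Cc2ncccc2CN1)[C@H]1CCCc2cccnc21` gives 37% on the same scale. Compound 4 `CCN(CC)CCCCN(C[C@H]1Cc2ncccc2CN1)[C@H]1CCCc2cccnc21` is still unmeasured and differs from compound 3 by a group of 8 heavy atoms (7 carbon, 1 nitrogen; no ring) in place of a group of 7 heavy atoms (4 carbon, 2 nitrogen, 1 oxygen; no ring), on a saturated chain carbon bound to an amine nitrogen with 3-(diethylamino)propyl as the entering group. Among the measured compounds shown here, three measured steps bear on this change. Large in size are a number 49 percentage points lower from compound 1 to compound 2 (beyond the scatter) and a number 76 percentage points lower from compound 1 to compound 3 (beyond the scatter) while a number 27 percentage points lower from compound 2 to compound 3 (beyond the scatter) is modest. For the measured compounds named here, the entering group resembles the 3-aminopropyl of compound 1 at 86% more closely than it resembles the group that leaves, yet no measured compound carries diethylamino, so only a partial climb back towards that number is expected. A large upward move is therefore expected, with a number 40 percentage points higher from compound 3 to compound 4 (beyond the scatter) as the estimated step. For compound 4 the estimated value is 50% with an expected range from 22% to 78% in this measurement.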

Compound 4, percent of the compound remaining: 1%
Compound 4: middle estimate off by 49 percentage points, on the high side; measured number below the stated range.
By their numbers in this assay, from the lowest: compounds 4 and 3 (each within the scatter of the next); then compound 2; then compound 1.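

In this assay, the saturated chain alone does not keep the compound intact: diethylamino in place of amino on a saturated chain carbon, four bonds along the chain from an amine nitrogen, gives a number 85 percentage points lower from compound 1 to compound 4 (beyond the scatter). So the group carried on that chain counts as well as the chain itself, and 3-(diethylamino)propyl in place of the unsaturated 3-aminoprop-1-en-1-yl gives a number 36 percentage points lower from compound 2 to compound 4 (beyond the scatter). The urea-bearing group of compound 3 and 3-(diethylamino)propyl cannot be told apart, with a number 9 percentage points lower from compound 3 to compound 4 (within the scatter), and nothing given here explains these differences.

Still open, as far as these compounds go, is whether methylamino or dimethylamino in place of amino on the same chain would stay close to compound 1 or fall towards compound 4. From the compounds shown here alone, a longer chain carrying amino is equally open.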